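Adding a Methoxy Group to the Aryl Ring of Compound 3

The compounds below may be only part of what the source reports. "The series", "measured", "known", "first", "only" and "open" are said of these compounds alone.

Compound 1 `Cc1cc(O)c(C2=NN(c3ccc(S(N)(=O)=O)cc3)C(c3ccccc3O)C2)cc1Cl` gives 16000 nM in a functional assay on OVCAR-4 cells (Homo sapiens) for antiproliferative activity, with a stated time of 48 h (a lower number here means a stronger inhibitor of growth, a higher number a weaker inhibitor of growth), compound 2 `Cc1cc(O)c(C2=NN(c3ccc(S(N)(=O)=O)cc3)C(/C=C/c3ccccc3)C2)cc1Cl` gives 18900 nM, and compound 3 `COc1ccc(C2CC(c3cc(Cl)c(C)cc3O)=NN2c2ccc(S(N)(=O)=O)cc2)cc1OC` gives 100000 nM, the highest of the three; the steps of a 6.3-fold higher number from compound 1 to compound 3 (0.80 log units; beyond the scatter) and a 5.3-fold higher number from compound 2 to compound 3 (0.72 log units; beyond the scatter) both lie beyond the scatter, while a 1.2-fold higher number from compound 1 to compound 2 (0.07 log units; within the scatter) does not. Compound 4 `COc1ccc(C2CC(c3cc(Cl)c(C)cc3O)=NN2c2ccc(S(N)(=O)=O)cc2)c(OC)c1OC` differs from compound 3 by methoxy in place of hydrogen on an aromatic carbon. Going by the values given here, none of the measured steps touches this position; all three exchange the whole group on the saturated ring carbon, so they give no guide to the size or direction of this change. A step of no change at the digits printed from compound 3 to compound 4 (within the scatter) in this assay is expected, not beyond the scatter. Compound 4 is estimated at 100000 nM, between 40000 nM and 200000 nM.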

Compound 4, concentration for total growth inhibition: 100000 nM
The estimate for compound 4 equals the measured number at the digits printed; measured number inside the range.
By their numbers in this assay, from the lowest: compounds 1 and 2 (each within the scatter of the next); then compounds 3 and 4 (each within the scatter of the next).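

In this assay, methoxy in place of hydrogen on an aromatic carbon, ortho to a large group and ortho to a methoxy group, gives no change at the digits printed from compound 3 to compound 4 (within the scatter) here, so this added group leaves the number unmoved. The 2,3,4-trimethoxyphenyl compound keeps the gap seen for compound 3, with a 5.3-fold higher number from compound 2 to compound 4 (0.72 log units; beyond the scatter) and a 6.3-fold higher number from compound 1 to compound 4 (0.80 log units; beyond the scatter) in this assay. No measured evidence accounts for this result.

Going by these compounds, whether an amine or a carboxylic acid on this aromatic carbon would shift the number remains open.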